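Side-chain change from compound 1 to compound 4

The source may hold more compounds than are shown below. What is called first, only, known or untested is meant among the compounds shown, and "the series" means these compounds.

Values in a functional assay on LNCaP cells (Homo sapiens) for antiproliferative activity; on this read-out higher numbers stand for weaker inhibition and lower numbers for stronger inhibition:
- compound 1 `Cn1ncc(Cl)c1-c1cc(C(=O)N[C@@H]2CN[C@H](CCN3CCC(O)CC3)C[C@H]2c2ccc(Cl)c(Cl)c2)oc1Cl`: 1140 nM
- compound 2 `CC(=O)NCC[C@@H]1C[C@@H](c2ccc(F)c(F)c2)[C@H](NC(=O)c2cc(-c3c(Cl)cnn3C)c(Cl)o2)CN1`: 130 nM
- compound 3 `C=CC[C@@H]1C[C@@H](c2ccc(Cl)c(Cl)c2)[C@H](NC(=O)c2cc(-c3c(Cl)cnn3C)c(Cl)o2)CN1`: 160 nM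

Not yet measured: compound 4 `CN(C)CC[C@@H]1C[C@@H](c2ccc(Cl)c(Cl)c2)[C@H](NC(=O)c2cc(-c3c(Cl)cnn3C)c(Cl)o2)CN1`.

Compound 1 has the highest number of the three in this assay. The change to compound 4 is dimethylamino in place of 4-hydroxypiperidin-1-yl on a saturated chain carbon, two bonds along the chain from a saturated ring carbon. Within the data shown here, the only measured step at this side chain is a 7.1-fold lower number from compound 1 to compound 3 (0.85 log units; beyond the scatter), where vinyl replaces (4-hydroxypiperidin-1-yl)methyl. Differing from compound 1 in more than one place, compound 2 also lies low at 130 nM. A lower number is therefore expected, with a step probably somewhat smaller than that one. The expected step is a 3.6-fold lower number from compound 1 to compound 4 (0.55 log units; beyond the scatter). Compound 4 is estimated at 320 nM, with an expected range of 120 nM to 850 nM.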

Compound 4, half-maximal inhibitory concentration: 1930 nM
Compound 4: middle estimate off by 6.0-fold (0.78 log units), on the low side, outside the stated range (above it).
By their numbers in this assay, from the lowest: compounds 2 and 3 (each within the scatter of the next); then compounds 1 and 4 (each within the scatter of the next).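

In this assay the exchange of 4-hydroxypiperidin-1-yl for dimethylamino gives a 1.7-fold higher number from compound 1 to compound 4 (0.23 log units; within the scatter), so the ring, its hydroxyl and the smaller heavy-atom count of dimethylamino leave no readable difference at this chain end. By contrast, (dimethylamino)methyl in place of vinyl gives a 12-fold higher number from compound 3 to compound 4 (1.08 log units; beyond the scatter), which places the two amine-ended chains together and apart from the vinyl chain. Only compound 3 stands on the lower side of that gap, so the gain seen with vinyl is not shared by either amine.

From the compounds shown here alone, whether a primary amine or a carboxylic acid at this chain end would fall with compound 3 or with compound 1 and compound 4 remains open. No available evidence accounts for the gap between the vinyl and amine-ended chains.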